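The compounds below may be only part of what the source reports. "The series", "measured", "known", "first", "only" and "open" are said of these compounds alone.

Three compounds share a core that carries a carboxylic acid through an ether link, and each has been measured in a physicochemical assay for solubility, read by HPLC, measured as thermodynamic solubility, with a stated time of 4 h, at pH 6.8; on this read-out higher numbers stand for higher solubility and lower numbers for lower solubility. Compound 1 `Cn1c(COc2cccc(C(=O)O)c2)nc2ccc(Oc3ccc4c(c3)OCC4)nc21` gives 17 ug/mL in this assay. Compound 2 `Cc1ccc(Oc2cc3c(cn2)nc(COc2cccc(C(=O)O)c2)n3C)cc1` gives 360 ug/mL in this assay. Compound 3 `Cc1ccc(Oc2ccc3nc(COc4cccc(C(=O)O)c4)n(C)c3c2)nc1` gives 31 ug/mL in this assay, which places it second highest of the three numbers: its value and that of compound 1 lie within the usual scatter of each other, so no order can be read between those two, while compound 2 stands beyond the scatter above compound 3.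

Compound 4 `Cc1cc(F)cnc1Oc1ccc2nc(COc3cccc(C(=O)O)c3)n(C)c2c1` has not yet been measured. Set against compound 3 it differs in one place: 5-fluoro-3-methylpyridin-2-yl in place of 5-methylpyridin-2-yl on an oxygen on an aromatic ring. Within the data shown here, no pair of measured compounds shows a change of this kind, so nothing measured tells what size of step it brings. The counted difference is small, and the step is therefore expected to be a 1.2-fold lower number from compound 3 to compound 4 (0.09 log units; within the scatter), none beyond the scatter. Compound 4 is expected to give about 25 ug/mL in this assay, with a range from 8 ug/mL to 80 ug/mL.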

Compound 4, solubility: 14 ug/mL
Estimate against measurement, compound 4: 1.8-fold (0.25 log units) above, and the stated range covers the measured number.
By their numbers in this assay, from the lowest: compounds 4, 1 and 3 (each within the scatter of the next, the first and the last beyond it); then compound 2.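

Among these compounds, this is the first step at this position that can be read in this assay, and 5-fluoro-3-methylpyridin-2-yl in place of 5-methylpyridin-2-yl on the oxygen gives a 2.2-fold lower number from compound 3 to compound 4 (0.35 log units; beyond the scatter) as a modest change that lies beyond the usual scatter. The two groups have the same counts of hydrogen-bond donors and acceptors and neither carries a net charge, so these counts do not separate them, yet a small swap on this oxygen is enough to move the number. No measurement of any property of these groups accompanies the result, so the data show the size of the step but offer no explanation for it.

The added fluorine and the different placing of the methyl arrive together in this single step, so the compounds shown cannot tell whether one of them alone accounts for the drop. Also open, as far as these compounds go, is whether an amine or a carboxylic acid in place of the fluorine would lead to a higher or a lower number in this assay than either compound here.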